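The compounds below may be only part of what the source reports. "The series", "measured", "known", "first", "only" and "open" are said of these compounds alone.

- Compound 1 `Cc1cc2[nH]c(=O)c(=O)[nH]c2c(N(CC(=O)O)S(C)(=O)=O)c1Cl`: 5%
- Compound 2 `CCc1c(Cl)cc2[nH]c(=O)c(=O)[nH]c2c1N(CCO)S(C)(=O)=O`: 1%

Both numbers come from an in vivo ADME assay on the whole organism (strain Sprague-Dawley) for pharmacokinetics, with Rattus norvegicus as the target, at a dose of 5 mg/kg by the oral route; on this read-out higher numbers stand for higher oral bioavailability and lower numbers for lower oral bioavailability. Compound 1 stands level with compound 2, as their two values lie within the usual scatter of each other, so neither can be ranked above the other. Compound 3 `Cc1cc2[nH]c(=O)c(=O)[nH]c2c(N(CCO)S(C)(=O)=O)c1Cl` is not yet measured. It differs from compound 1 in a single group, with hydroxymethyl in place of carboxy on a saturated chain carbon bound to a sulfonamide nitrogen. Going by the values given here, no measured pair shows a change of this kind, so any expectation rests on thin evidence. Compound 1 at 5% and compound 2 at 1% offer no sign of a large change. In this assay, the expected step is a number 1 percentage points higher from compound 1 to compound 3 (within the scatter), which stays within the scatter. For compound 3, the estimated value is 6%, with an expected range of 1% to 20%.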

Compound 3, oral bioavailability in the Rattus norvegicus assay: 9%
Estimate against measurement, compound 3: 3 percentage points below, and the stated range covers the measured number.
By their numbers in the Rattus norvegicus assay, from the lowest: compounds 2, 1 and 3 (each within the scatter of the next).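

Swapping carboxy for hydroxymethyl on a saturated chain carbon bound to a sulfonamide nitrogen is the first change here that can be read in one place. In the Rattus norvegicus assay compound 1 gives 5% and compound 3 gives 9% so the swap gives a number 4 percentage points higher from compound 1 to compound 3 (within the scatter) and leaves the two compounds level. In a physicochemical assay for solubility (a lower number here means a less soluble compound, a higher number a more soluble compound), compound 1 gives 72 ug/mL and compound 3 gives 70 ug/mL so the same swap gives a 1.0-fold lower number from compound 1 to compound 3 (0.01 log units; within the scatter) and again leaves them level, so at this position the change moved neither read-out beyond ordinary repeat variation. Nothing available explains why these two groups read alike.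

As far as these compounds go, whether a longer chain or an amine at the same position would separate from these compounds in oral bioavailability remains open. Going by these compounds alone, also open is whether the same swap would read alike on a different core, since this single pair is the only example of it.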